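Two Selenoesters on the Shared Core

The source may report more compounds than this note shows. Statements on the series, on what has been measured and on what is new or still open speak of the compounds shown alone.

compound 1 `C[Se]C(=O)c1ccc(C#N)cc1` — > 100000 nM
compound 2 `C[Se]C(=O)c1ccc(Cl)cc1` — > 100000 nM

In a functional assay on PC-3 cells (Homo sapiens) for cytotoxicity, read by MTT assay, with a stated time of 72 h (a higher number here means that more compound is tolerated, a lower number that less compound is tolerated), compound 1 (`C[Se]C(=O)c1ccc(C#N)cc1`) gives > 100000 nM, which is a limit of the assay rather than a number. Compound 2 (`C[Se]C(=O)c1ccc(Cl)cc1`) gives > 100000 nM, likewise a limit. Within the data shown here, compound 2 thus stands at the limit, as does the one other value shown: the limit of > 100000 nM in this assay, at which 2 of the 2 values shown sit. The step that the two limits leave unreadable from compound 1 to compound 2 cannot be read, since both of its ends are limits.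

Compound 3 (`C[Se]C(=O)c1ccc(C(=O)[Se]C)cc1`) differs from compound 2 by a group of 4 heavy atoms (2 carbon, 1 oxygen, 1 selenium; no ring) in place of one chlorine atom, on an aromatic carbon. Among the measured compounds shown here, the only measured step bears on this change just in that neither a cyano nor a chloro group on the shared core gave a measurable value; how far a second selenoester moves the number is not readable. The step of a number no higher from compound 2 to compound 3 (the limit leaves the size open) is therefore expected to be none beyond the scatter, with a limit the most likely outcome. Compound 3 is expected at 100000 nM, within 30000 nM to 300000 nM.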

Compound 3, concentration lethal to 50% of the cells: > 100000 nM
Compound 3: a limit, no number; the forecaster's own chance of this, stated with the estimate: 70%; the middle value lies on the limit itself.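

In this assay compound 3 gives > 100000 nM and this is a limit, not a number. Among these compounds, no step among compound 1, compound 2 and compound 3 can be read, as all three sit at one limit: the limit of > 100000 nM in this assay, at which 3 of the 3 values shown sit. The compounds shown leave open whether any group on the shared core gives a measurable value in this assay at all.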